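Notes on the step from compound 3 to compound 4

The compounds below may be only part of what the source reports. "The series", "measured", "known", "first", "only" and "open" are said of these compounds alone.

Of the compounds shown here, three have been read in an in vitro ADME assay on microsomes (Homo sapiens) for metabolic stability; on this read-out higher numbers stand for a longer-lived compound and lower numbers for a shorter-lived compound. Compound 1 `CCc1nc(NC(CC)CC)cnc1-c1ccc(Cl)cc1Cl` gives 0.467 h. Compound 2 `CCc1nc(-c2ccc(Cl)cc2Cl)c(CC)nc1NC(COC)COC` gives 0.15 h, and compound 3 `CCc1nc(-c2ccc(Cl)cc2Cl)c(CC)nc1NC(C)CN(C)C` gives 0.117 h. Compound 3 therefore sits at the low end of the three numbers, level within the scatter with compound 2, while compound 1 stands clearly above it.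

The next change leads to compound 4 `CCc1nc(-c2ccc(Cl)cc2Cl)c(CC)nc1NC(CC)CC`: pentan-3-yl in place of 1-((dimethylamino)methyl)ethyl on a nitrogen on an aromatic ring. In words, pentan-3-yl takes the place of 1-((dimethylamino)methyl)ethyl on a nitrogen on an aromatic ring.

For the measured compounds named here, the one measured step at this place is a 1.3-fold lower number from compound 2 to compound 3 (0.11 log units; within the scatter), and it stays within the scatter. Going by the values given here, the pentan-3-yl group also occurs in compound 1 at 0.467 h, but on a different core from the one shared by compound 2, compound 3 and compound 4. Among the compounds with values here, no measured step links that core to the shared one, so this value lifts the expectation only slightly.

No step beyond the scatter is therefore expected in this assay. The estimated step is a 1.4-fold higher number from compound 3 to compound 4 (0.14 log units; within the scatter). Compound 4 is expected at 0.16 h, with an estimated range of 0.08 h to 0.35 h.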

Compound 4, half-life: 0.283 h
For compound 4 the middle estimate is 1.8-fold (0.25 log units) below the measured one, and the stated range covers the measured number.
By their numbers in this assay, from the lowest: compounds 3, 2, 4 and 1 (each within the scatter of the next, the first and the last beyond it).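

Working notes on the series: in this assay, the exchange of 1-((dimethylamino)methyl)ethyl for pentan-3-yl on a nitrogen on an aromatic ring gives a 2.4-fold higher number from compound 3 to compound 4 (0.38 log units; beyond the scatter), the first step at this position beyond the scatter, though still a modest one, while the exchange of 2-methoxy-1-(methoxymethyl)ethyl for pentan-3-yl gives a 1.9-fold higher number from compound 2 to compound 4 (0.28 log units; within the scatter) and stays within the scatter. For the compounds shown here, the two cores are now linked for the first time: ethyl in place of hydrogen on an aromatic carbon, with pentan-3-yl held constant, gives a 1.7-fold lower number from compound 1 to compound 4 (0.22 log units; within the scatter), so this change does not separate the two compounds beyond the scatter. No measurement available here accounts for either step.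

Going by these compounds alone, compound 1 is the only compound on its core, so it remains open whether the 1-((dimethylamino)methyl)ethyl and 2-methoxy-1-(methoxymethyl)ethyl groups would read the same way there. On these data alone, it is also open how a cyclopentyl group, a longer chain such as heptan-4-yl or a chain ending in a carboxylic acid would read on the same nitrogen of the shared core.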